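Replacing the 4-fluorophenyl of compound 1 with 2,3-dihydroxyphenyl

A few compounds are considered here, and "the series" means these few. Any claim that something is new, unique, unknown or untested is made for them only; others in the source may bear on it.

Among the compounds with values here, compound 1 `OC[C@H]1O[C@@H](n2cnc3c(NCc4ccc(F)cc4)ncnc32)[C@H](O)[C@@H]1O` holds the lowest number of the three measured members: in a functional assay on K562 cells (Homo sapiens) for antiproliferative activity, with a stated time of 72 h (on this read-out lower numbers stand for stronger inhibition and higher numbers for weaker inhibition), compound 1 gives 2700 nM. Compound 2 `OC[C@H]1O[C@@H](n2cnc3c(NCc4ccccc4Cl)ncnc32)[C@H](O)[C@@H]1O` gives 64000 nM and compound 3 `OC[C@H]1O[C@@H](n2cnc3c(NCc4ccc(Br)cc4)ncnc32)[C@H](O)[C@@H]1O` gives 68200 nM. Both departures from the 4-fluorophenyl of compound 1 cost heavily: a 24-fold higher number from compound 1 to compound 2 (1.37 log units; beyond the scatter) and a 25-fold higher number from compound 1 to compound 3 (1.40 log units; beyond the scatter), while a 1.1-fold higher number from compound 2 to compound 3 (0.03 log units; within the scatter).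

Compound 4 `OC[C@H]1O[C@@H](n2cnc3c(NCc4cccc(O)c4O)ncnc32)[C@H](O)[C@@H]1O` differs from compound 1 as follows: 2,3-dihydroxyphenyl in place of 4-fluorophenyl on a saturated chain carbon bound to a nitrogen on an aromatic ring. Within the data shown here, no measured step swaps the halogen for hydroxyl groups, so the change is only indirectly covered. The two steps that bear on it, from compound 1 to compound 2 and from compound 1 to compound 3, both show that altering the 4-fluorophenyl group raises the number by a large margin in this assay. A higher number for compound 4 than for compound 1 is therefore expected, roughly of the size seen in those two steps, with wide uncertainty given the new group: an 11-fold higher number from compound 1 to compound 4 (1.05 log units; beyond the scatter). The estimate for compound 4 is 30000 nM, between 5000 nM and 150000 nM.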

Compound 4, half-maximal inhibitory concentration: 25800 nM
For compound 4 the middle estimate is 1.2-fold (0.07 log units) above the measured one, within the range that was stated.
By their numbers in this assay, from the lowest: compound 1; then compound 4; then compounds 2 and 3 (each within the scatter of the next).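

At this position, on a saturated chain carbon bound to a nitrogen on an aromatic ring, 2,3-dihydroxyphenyl carries hydrogen-bond donors where 4-fluorophenyl has none, and in this assay the result is a 9.6-fold higher number from compound 1 to compound 4 (0.98 log units; beyond the scatter). The same group recovers part of the ground lost with the other two aryl groups, giving a 2.6-fold lower number from compound 3 to compound 4 (0.42 log units; beyond the scatter) and a 2.5-fold lower number from compound 2 to compound 4 (0.39 log units; beyond the scatter), so the replacements of 4-fluorophenyl shown here do not all cost the same amount. No measurement on hand accounts for this order of groups.

Still open is whether the difference from compounds 2 and 3 needs both hydroxyl groups or just one, and a phenyl ring with a single hydroxyl group is not among the compounds shown. Also open, going by these compounds, is how an amine or a carboxylic acid on the phenyl ring would read in this assay.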